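A few compounds are considered here, and "the series" means these few. Any claim that something is new, unique, unknown or untested is made for them only; others in the source may bear on it.

Measured compounds:
- compound 1, `CCCCCCCCCCCCCCNC(=O)[C@@H](NC(=O)c1cc2ccccc2n1C)[C@@H](C)O`: 34500 nM
- compound 2, `CCCCCCCCCCCCCCNC(=O)[C@@H](NC(=O)/C=C/c1ccccc1)[C@@H](C)O`: 150000 nM
- compound 3, `CCCCCCCCCCCCCCCCCCNC(=O)[C@@H](NC(=O)c1cc2ccccc2n1C)[C@@H](C)O`: > 200000 nM

All three values come from a functional assay on HepG2 cells (Homo sapiens) for cytotoxicity, read by MTT assay, with a stated time of 48 h; on this read-out lower numbers stand for stronger inhibition and higher numbers for weaker inhibition. The value of compound 3 in this assay is a limit of the assay, not a number, and it sits at the limit of > 200000 nM in this assay, at which 1 of the 3 values shown sits.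

Two changes are covered. The first, (2-phenylethenyl in place of 1-methyl-1H-indol-2-yl on a carbonyl carbon), gives a 4.3-fold higher number from compound 1 to compound 2 (0.64 log units; beyond the scatter). The second concerns how the two cores differ, (butyl in place of hydrogen on a saturated chain carbon, ten or more bonds along the chain from an amide-type nitrogen), and gives an at least 5.7-fold higher number from compound 1 to compound 3 (0.76 log units; beyond the scatter), with compound 3 reported only as a limit.

Compound 4, `CCCCCCCCCCCCCCCCCCNC(=O)[C@@H](NC(=O)/C=C/c1ccccc1)[C@@H](C)O`, has not yet been tested in this assay. It differs from compound 3 by 2-phenylethenyl in place of 1-methyl-1H-indol-2-yl on a carbonyl carbon. The "place" is the same word for word as between compound 1 and compound 2, so this is the same change made on the other core.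

Compound 3 already sits at the limit, and the same change on compound 1 moved the number upward by a 4.3-fold higher number from compound 1 to compound 2 (0.64 log units; beyond the scatter). It is therefore expected that compound 4 moves by about a step that the limit leaves unreadable from compound 3 to compound 4. Compound 4 is estimated at 600000 nM in this assay, with a range from 200000 nM to 2000000 nM; most of the time this assay should report only a limit for it and no number.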

Compound 4, half-maximal inhibitory concentration: 128000 nM
The estimate for compound 4 lay 4.7-fold (0.67 log units) above the measured number; measured number below the stated range.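

In this assay, 2-phenylethenyl in place of 1-methyl-1H-indol-2-yl on a carbonyl carbon does not carry a fixed step from one core to the other: on the core of compound 3 it gives an at least 1.5-fold lower number from compound 3 to compound 4 (0.19 log units; that floor lies within the scatter), a floor and not a full step, and this does not match the step on the core of compound 1: the same change on two cores in this assay, a 4.3-fold higher number (0.64 log units; beyond the scatter) from compound 1 to compound 2 and an at least 1.5-fold lower number (0.19 log units; that floor lies within the scatter) from compound 3 to compound 4, at least 6.7-fold (0.83 log units) apart, beyond the scatter of two such steps

Read along the other edge of the same four compounds, butyl in place of hydrogen on a saturated chain carbon gives a 1.2-fold lower number from compound 2 to compound 4 (0.07 log units; within the scatter), so the outcome of that change also depends on the group on the carbonyl carbon: the same change on two cores in this assay, an at least 5.7-fold higher number (0.76 log units; beyond the scatter) from compound 1 to compound 3 and a 1.2-fold lower number (0.07 log units; within the scatter) from compound 2 to compound 4, at least 6.7-fold (0.83 log units) apart, beyond the scatter of two such steps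

This shows that the two changes do not add up across these four compounds, but it does not give the true size of the step on the core of compound 3, offers no reason for the mismatch and sets no rule for other groups in the series.

Open, from the compounds shown here alone, is whether a hexadecyl chain would fall with the tetradecyl or the octadecyl compounds when 1-methyl-1H-indol-2-yl is kept. Also open, going by these compounds, is whether a plain phenyl group on the carbonyl carbon would follow 2-phenylethenyl and show the same lack of response to chain length.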